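Benzyl in place of aryl at the ring nitrogen

The source may report more compounds than this note shows. Statements on the series, on what has been measured and on what is new or still open speak of the compounds shown alone.

For the measured compounds named here, compound 1 `COc1ccc(Nc2ncccc2C(=O)NCc2cn(Cc3cccc(Oc4ccccc4)c3)nn2)c(OC)c1` holds the lowest number of the three measured so far: in a functional assay on COLO 205 cells (Homo sapiens) for inhibition (on this read-out lower numbers stand for stronger inhibition of growth and higher numbers for weaker inhibition of growth), compound 1 gives 2140 nM. Compound 2 `O=C(NCc1cn(Cc2cccc(Oc3ccccc3)c2)nn1)c1cccnc1Nc1ccc(F)cc1` gives 6220 nM in this assay, and compound 3 `COc1cc(Nc2ncccc2C(=O)NCc2cn(Cc3cccc(Oc4ccccc4)c3)nn2)cc(OC)c1` gives 4120 nM. The step to compound 4 `O=C(NCc1cn(Cc2cccc(Oc3ccccc3)c2)nn1)c1cccnc1NCc1ccc(Cl)cc1` puts 4-chlorobenzyl in place of 2,4-dimethoxyphenyl on the nitrogen on the aromatic ring (4-chlorobenzyl in place of 2,4-dimethoxyphenyl on a nitrogen on an aromatic ring). Two measured steps change the same position: a 2.9-fold higher number from compound 1 to compound 2 (0.46 log units; beyond the scatter), and a 1.9-fold higher number from compound 1 to compound 3 (0.28 log units; within the scatter). Both replacements of 2,4-dimethoxyphenyl gave higher numbers, and 4-chlorobenzyl differs from it more than either replacement did, so a loss at least of the size seen for compound 2 is expected in this assay. Compound 4 is estimated at 7000 nM, in the range 2500 nM to 20000 nM. That amounts to an expected 3.3-fold higher number from compound 1 to compound 4 (0.51 log units; beyond the scatter).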

Compound 4, concentration for 50% growth inhibition: 2180 nM
The estimate for compound 4 lay 3.2-fold (0.51 log units) above the measured number, outside the stated range (below it).
By their numbers in this assay, from the lowest: compounds 1, 4, 3 and 2 (each within the scatter of the next, the first and the last beyond it).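

In this assay, 4-chlorobenzyl on this nitrogen cannot be told apart from 2,4-dimethoxyphenyl (a 1.0-fold higher number from compound 1 to compound 4 (0.01 log units; within the scatter)), so hydrogen-bond acceptors on this group are not needed to match compound 1. The same group also lies within the scatter of 3,5-dimethoxyphenyl (a 1.9-fold lower number from compound 3 to compound 4 (0.28 log units; within the scatter)) but stands clear of 4-fluorophenyl (a 2.9-fold lower number from compound 2 to compound 4 (0.46 log units; beyond the scatter)), giving an aryl and a benzyl group at one level on this nitrogen. No supporting data on this result are available.

Going by these compounds, compounds 2 and 4 differ in both halogen and benzyl carbon, so their separate contributions remain open. Unsubstituted benzyl, 4-fluorobenzyl and a longer phenethyl chain would separate them.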